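The source may hold more compounds than are shown below. What is called first, only, known or untested is meant among the compounds shown, and "the series" means these compounds.

Within the data shown here, compound 1 `CCC1=C(O)c2c(oc(-c3ccc(C)cc3)cc2=O)C(CC)(CC)C1=O` is the higher of the two numbers so far in a functional assay on KB cells (Homo sapiens) for antiproliferative activity, read by sulforhodamine B assay, with a stated time of 3 days (a higher number here means that more compound is needed for the effect, a lower number that less compound is needed), where compound 1 gives 39.2 uM. Among the measured compounds shown here, compound 2 `CCC1=C(O)c2c(oc(-c3ccc(C(C)C)cc3)cc2=O)C(CC)(CC)C1=O` gives 8.13 uM in this assay, and the one measured step, a 4.8-fold lower number from compound 1 to compound 2 (0.68 log units; beyond the scatter), follows from putting isopropyl in place of methyl on an aromatic carbon. Compound 3 `CCC1=C(O)c2c(oc(-c3ccc(C(F)(F)F)cc3)cc2=O)C(CC)(CC)C1=O` differs from compound 1 by trifluoromethyl in place of methyl on an aromatic carbon. For the measured compounds named here, only that single step bears on this change, and it involves a different group, so a small lowering beyond the scatter is expected, giving compound 3 an estimated 20 uM (range 6 uM to 60 uM), a step of a 2.0-fold lower number from compound 1 to compound 3 (0.29 log units; within the scatter).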

Compound 3, concentration for half-maximal effect: 35.7 uM
Compound 3: middle estimate off by 1.8-fold (0.25 log units), on the low side, and the stated range covers the measured number.
By their numbers in this assay, from the lowest: compound 2; then compounds 3 and 1 (each within the scatter of the next).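

In this assay, trifluoromethyl and methyl at this position cannot be told apart (a 1.1-fold lower number from compound 1 to compound 3 (0.04 log units; within the scatter)), whereas isopropyl remains clearly separate from trifluoromethyl (a 4.4-fold higher number from compound 2 to compound 3 (0.64 log units; beyond the scatter)). The lower number seen with isopropyl therefore does not carry over to every replacement of methyl on this aromatic carbon. No measurement shown explains why these groups differ.

Going by these compounds, it remains open whether a tert-butyl group or a longer chain would follow isopropyl. It is also unclear how an amine or a carboxylic acid at this position would compare.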